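Solubility After Swapping the Aryl Group on the Core

This account rests on a few compounds, and the source may have more. Where it says the series, first, only, none or still open, it means among the compounds named here.

Measured compounds:
compound 1 `Cc1cccc(-c2nc(CN3CCC(C(=O)NCCCN4C[C@H](C)C[C@H](C)C4)CC3)c(C)o2)c1` – > 69 ug/mL
compound 2 `COc1cccc(Br)c1-c1nc(CN2CCC(C(=O)NCCCN3C[C@H](C)C[C@H](C)C3)CC2)c(C)o1` – > 83 ug/mL

In a physicochemical assay for solubility, in phosphate buffer, measured as kinetic solubility, at pH 7.4 (on this read-out higher numbers stand for higher solubility and lower numbers for lower solubility), compound 1 gives > 69 ug/mL, which is a limit of the assay rather than a number. In the same assay compound 2 gives > 83 ug/mL, again a limit and not a number. For that reason the step that the two limits leave unreadable from compound 1 to compound 2 cannot be read, and compound 2 stands only at a limit, as the two limits the limit of > 69 ug/mL in this assay, at which 1 of the 2 values shown sits, and the limit of > 83 ug/mL in this assay, at which 1 of the 2 values shown sits, show.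

Compound 3 `Cc1ccc(-c2nc(CN3CCC(C(=O)NCCCN4C[C@H](C)C[C@H](C)C4)CC3)c(C)o2)c(C)c1` has not yet been measured. It differs from compound 2 in one place: 2,4-dimethylphenyl in place of 2-bromo-6-methoxyphenyl on an aromatic carbon. For the measured compounds named here, the only measured step touches the same position but gives no readable size, so no direction can be taken from it. Since both measured compounds sit at a limit, compound 3 is expected to reach a comparable level, with the step of an at least 1.0-fold lower number from compound 2 to compound 3 (0.01 log units; that floor lies within the scatter) estimated as flat. In this assay compound 3 is expected to give about 80 ug/mL, within 40 ug/mL to 160 ug/mL.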

Compound 3, solubility: > 71 ug/mL
Compound 3: a limit, no number; the forecaster's own chance of this, stated with the estimate: 65%; the middle value does not contradict the limit.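

In this assay compound 3 gives > 71 ug/mL, a limit of the assay and not a number. Compound 1 and compound 2 also stand at limits, so no step among these three compounds can be read. The compounds shown leave open whether their three aryl groups differ at all in this assay.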